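A Chloro Added to Compound 2: Little Change Expected

The source may hold more compounds than are shown below. What is called first, only, known or untested is meant among the compounds shown, and "the series" means these compounds.

Compound 1 `Cn1c(N2N=C(c3ccc(Cl)cc3)CC2c2ccccc2)nc(-c2ccccc2)c(C#N)c1=O` gives 26900 nM in a functional assay on A549 cells (Homo sapiens) for antiproliferative activity, with a stated time of 72 h; a lower number here means a stronger inhibitor, a higher number a weaker inhibitor.
Compound 2 `Cn1c(N2N=C(c3ccccc3)CC2c2ccccc2)nc(-c2ccc(Cl)cc2)c(C#N)c1=O` gives 28100 nM in this assay.
Compound 3 `Cn1c(N2N=C(c3ccccc3)CC2c2ccc(F)cc2)nc(-c2ccc(Cl)cc2)c(C#N)c1=O` gives 27800 nM in this assay.

Of these three numbers, compound 2's is nominally the highest, but its gaps to compound 3 and to compound 1 both lie within the scatter, so no real order can be read among them. Compound 4 `Cn1c(N2N=C(c3ccc(Cl)cc3)CC2c2ccccc2)nc(-c2ccc(Cl)cc2)c(C#N)c1=O` differs from compound 2 by chloro in place of hydrogen on an aromatic carbon. For the measured compounds named here, the one measured step that bears on this is a 1.0-fold lower number from compound 2 to compound 3 (0.00 log units; within the scatter), another halogen entering on an aromatic carbon, and it lies within the scatter. Compound 1, which carries a chloro and a phenyl in the swapped arrangement, also sits within the scatter of compound 2. A step of about a 1.0-fold lower number from compound 2 to compound 4 (0.00 log units; within the scatter) is therefore expected, none beyond the scatter. Compound 4 is estimated at 28000 nM, with a range from 14000 nM to 56000 nM.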

Compound 4, half-maximal inhibitory concentration: 43900 nM
Beside the measured number, compound 4's estimate is 1.6-fold (0.20 log units) below it; the range from low to high includes it.
By their numbers in this assay, from the lowest: compounds 1, 3, 2 and 4 (each within the scatter of the next).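

In this assay the change from phenyl to 4-chlorophenyl gives a 1.6-fold higher number from compound 2 to compound 4 (0.19 log units; within the scatter) and, on the other aromatic ring, a 1.6-fold higher number from compound 1 to compound 4 (0.21 log units; within the scatter) with the same change. For the compounds shown here, compound 4 is the first compound here with a chloro on both rings, and it shows that the second chloro, whichever ring receives it, leaves the number within the scatter. No supporting measurement bears on this result.

Going by these compounds, whether an amine, a carboxylic acid or a methoxy group in this place would give a step beyond the scatter remains open.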